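The source may hold more compounds than are shown below. What is called first, only, known or untested is meant among the compounds shown, and "the series" means these compounds.

Three glycosides of the shared core have been measured in a functional assay on RAW264.7 cells (Mus musculus) for inhibition, read by Griess assay, with a stated time of 24 h; a higher number here means a weaker inhibitor, a lower number a stronger inhibitor. Compound 1 `O=C1C[C@@H](O[C@H]2O[C@H](CO)[C@@H](O)[C@H](O)[C@H]2O)CN1` gives 89000 nM. Compound 2 `O=C1C[C@H](O[C@H]2O[C@H](CO)[C@@H](O)[C@H](O)[C@@H]2O)CN1` gives 67100 nM, and a 1.3-fold lower number from compound 1 to compound 2 (0.12 log units; within the scatter). Compound 3 `C[C@@H]1O[C@@H](O[C@@H]2CNC(=O)C2)[C@H](O)[C@H](O)[C@H]1O` gives 66900 nM; this is the lowest of the three numbers, yet it sits within the scatter of both others, so no ordering among them can be claimed. Compound 4 `C[C@@H]1O[C@@H](O[C@H]2CC(=O)N(Cc3ccccc3)C2)[C@H](O)[C@H](O)[C@H]1O` differs from compound 3 by benzyl in place of hydrogen on an amide-type nitrogen in a ring. Going by the values given here, the only measured step concerns configuration alone and does not touch the amide-type nitrogen in the ring, so it gives no guide to this change. With nothing to anchor a shift, the expected step of a 1.1-fold lower number from compound 3 to compound 4 (0.05 log units; within the scatter) is none beyond the scatter, carrying a wide range. Compound 4 is accordingly estimated at 60000 nM, between 15000 nM and 200000 nM.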

Compound 4, half-maximal inhibitory concentration: 69700 nM
For compound 4 the middle estimate is 1.2-fold (0.07 log units) below the measured one; low and high end bracket the measured number.
By their numbers in this assay, from the lowest: compounds 3, 2, 4 and 1 (each within the scatter of the next).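

In this assay, going by these compounds alone, putting benzyl on the amide-type nitrogen in the ring gives a 1.0-fold higher number from compound 3 to compound 4 (0.02 log units; within the scatter), the first reading at this position. The amide hydrogen can therefore give way to benzyl with the number remaining within the scatter, though this rests on a single pair. Nothing available bears on why this step is so small.

From the compounds shown here alone, whether a different group on this nitrogen, such as an amine-bearing chain or a carboxylic acid, would move the number beyond the scatter remains open.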